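Swapping a chlorophenyl for a pyridinyl on an aryl amide

The source may report more compounds than this note shows. Statements on the series, on what has been measured and on what is new or still open speak of the compounds shown alone.

Compound 1 `O=C(CCc1ccc(-c2ccc(F)cc2)cc1)N1CCCC1` gives 3400 nM in an assay on HEK293 cells for inhibition of N-acylethanolamine-hydrolyzing acid amidase (Rattus norvegicus), read by LC-MS, with a stated time of 30 min; on this read-out higher numbers stand for weaker inhibition and lower numbers for stronger inhibition.
Compound 2 `O=C(CCc1ccc(-c2ccccc2Cl)cc1)N1CCCC1` gives > 100000 nM in this assay.

The value of compound 2 is a limit of the assay, not a number: it sits at the limit of > 100000 nM in this assay, at which 1 of the 2 values shown sits, so compound 2 stands at the weak end of what can be seen. The next compound, compound 3 `O=C(CCc1ccc(-c2cccnc2)cc1)N1CCCC1`, differs from compound 2 in one place: pyridin-3-yl in place of 2-chlorophenyl on an aromatic carbon. For the measured compounds named here, only one measured step bears on this position, the change of the outer ring in an at least 29-fold higher number from compound 1 to compound 2 (1.46 log units; beyond the scatter), and it was large. Returning from a 2-chlorophenyl to a flat ring without a substituent on carbon may recover part of that loss, though the new ring is not the fluorophenyl of compound 1, so the size is uncertain. Compound 3 is expected to give 20000 nM, with a range from 4000 nM to 100000 nM. This corresponds to an estimated step of an at least 5.0-fold lower number from compound 2 to compound 3 (0.69 log units; beyond the scatter).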

Compound 3, half-maximal inhibitory concentration: > 100000 nM
Compound 3: no number, only a limit (the forecaster's own chance of this, stated with the estimate: 30%); at least 5.0-fold (0.69 log units) between middle value and limit.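

In this assay compound 3 gives > 100000 nM, which is a limit of the assay and not a number. Pyridin-3-yl in place of 4-fluorophenyl gives an at least 29-fold higher number from compound 1 to compound 3 (1.46 log units; beyond the scatter), so a second replacement of the outer ring also loses the measurable inhibition, and among the three rings shown only the 4-fluorophenyl leaves a readable value. Compound 2 and compound 3 both sit at the limit, so the step between them cannot be read and neither ring can be ranked against the other: the limit of > 100000 nM in this assay, at which 2 of the 3 values shown sit.

Going by these compounds, whether a plain phenyl, a 4-chlorophenyl or a pyridin-4-yl at this place would keep any of the inhibition seen with compound 1 stays open. How far past the limit the true values of compound 2 and compound 3 lie is also unknown.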